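Shortening the Urea Substituent from Cyclohexylmethyl to Cyclohexyl

The source may hold more compounds than are shown below. What is called first, only, known or untested is meant among the compounds shown, and "the series" means these compounds.

Compound 1 `COc1cc(NC(C)CCCNC(=O)NCC2CCCCC2)c2ncccc2c1`: 61000 nM
Compound 2 `COc1cc(NC(C)CCCNC(=O)NC2CCCC2)c2ncccc2c1`: 19000 nM

Among the compounds with values here, in a functional assay on SW-620 cells (Homo sapiens), read by MTT assay, with a stated time of 72 h (a lower number here means a stronger inhibitor, a higher number a weaker inhibitor), compound 1 gives 61000 nM, the highest of the two numbers so far. Within the data shown here, the one measured step, a 3.2-fold lower number from compound 1 to compound 2 (0.51 log units; beyond the scatter), came from cyclopentyl in place of cyclohexylmethyl on an amide-type nitrogen. Compound 3 `COc1cc(NC(C)CCCNC(=O)NC2CCCCC2)c2ncccc2c1` differs from compound 1 by cyclohexyl in place of cyclohexylmethyl on an amide-type nitrogen. Among the measured compounds shown here, only that step bears on the change, and both changes take away the cyclohexylmethyl group, so a step in the same direction is expected for compound 3, namely a 2.0-fold lower number from compound 1 to compound 3 (0.31 log units; beyond the scatter), most likely smaller. Compound 3 is therefore estimated at 30000 nM, in a range from 12000 nM to 75000 nM.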

Compound 3, half-maximal inhibitory concentration: 49000 nM
For compound 3 the middle estimate is 1.6-fold (0.21 log units) below the measured one; measured number inside the range.
By their numbers in this assay, from the lowest: compound 2; then compounds 3 and 1 (each within the scatter of the next).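

In this assay, cyclohexyl in place of cyclohexylmethyl on the amide-type nitrogen gives a 1.2-fold lower number from compound 1 to compound 3 (0.10 log units; within the scatter) and so, unlike the earlier step to compound 2, no change beyond the scatter. Going the other way, cyclohexyl in place of cyclopentyl gives a 2.6-fold higher number from compound 2 to compound 3 (0.41 log units; beyond the scatter) and shows that the lower number of compound 2 goes with the cyclopentyl group, not with the loss of cyclohexylmethyl alone. Nothing available explains this difference.

The compounds shown leave open whether cyclobutyl would extend the step seen with cyclopentyl. They also leave open how an open chain such as n-butyl, or a ring carrying an amine such as piperidinyl, would behave on this nitrogen.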